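Swapping the Aryl Group of a Hydrazone Paw-Edema Series

The source may hold more compounds than are shown below. What is called first, only, known or untested is meant among the compounds shown, and "the series" means these compounds.

Measured compounds:
Compound 1, `O=C(N/N=C/c1cccc(F)c1)c1cccnc1Nc1cccc(C(F)(F)F)c1`: 37%
Compound 2, `O=C(N/N=C/c1ccc(F)cc1)c1cccnc1Nc1cccc(C(F)(F)F)c1`: 41.3%
Compound 3, `O=C(N/N=C/c1ccc(O)c(O)c1)c1cccnc1Nc1cccc(C(F)(F)F)c1`: 38.2%

Of the compounds shown here, three sharing one core have been tested in a functional assay on the whole organism (strain Wistar) for inhibition, with Rattus norvegicus as the target, read by paw edema, with a stated time of 3 h, at a dose of 10 mg/kg by the intraperitoneal route; a higher number here means more inhibition at the dose given (going by the name of the read-out), a lower number less inhibition. Compound 2 has the highest number of the three, but the gaps to its neighbours are small: a number 3.1 percentage points lower from compound 2 to compound 3 (within the scatter) and a number 4.3 percentage points higher from compound 1 to compound 2 (within the scatter) are both within the scatter, so none of the three can be set apart from the others. The step from compound 1 to compound 3, a number 1.2 percentage points higher from compound 1 to compound 3 (within the scatter), is likewise within the scatter.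

Compound 4, `COc1ccc(/C=N/NC(=O)c2cccnc2Nc2cccc(C(F)(F)F)c2)c(OC)c1`, has not yet been measured. Compared with compound 2, the change is 2,4-dimethoxyphenyl in place of 4-fluorophenyl on a carbon with a double bond to nitrogen. Within the data shown here, no measured step replaces one aryl group with a dimethoxy-bearing one, so the closest guides are the swaps already seen at the same carbon: a fluorine moved within the ring in a number 4.3 percentage points higher from compound 1 to compound 2 (within the scatter) and two hydroxy groups put in place of fluorine in a number 3.1 percentage points lower from compound 2 to compound 3 (within the scatter). Both stayed within the scatter. On that basis no step beyond the scatter is expected in this assay for compound 4, and its estimated value is 38%, with a range from 25% to 51%. The step this estimate implies, a number 3.3 percentage points lower from compound 2 to compound 4 (within the scatter), is expected to be small.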

Compound 4, a percentage reported as inhibition, in the whole organism at one dose (the size of the read-out at that dose, not a potency): 24.1%
For compound 4 the middle estimate is 13.9 percentage points above the measured one; the measured number lies below the stated range.
By their numbers in this assay, from the lowest: compound 4; then compounds 1, 3 and 2 (each within the scatter of the next).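

In this assay the aryl group on the carbon with a double bond to nitrogen can now be seen to matter, with a number 17.2 percentage points lower from compound 2 to compound 4 (beyond the scatter) and also a number 14.1 percentage points lower from compound 3 to compound 4 (beyond the scatter) and also a number 12.9 percentage points lower from compound 1 to compound 4 (beyond the scatter) for the 2,4-dimethoxyphenyl group. The swaps among 3-fluorophenyl, 4-fluorophenyl and 3,4-dihydroxyphenyl had shown no difference that could be told from the scatter, so this position looked open to change, whereas compound 4 is now the one compound set apart, with the lowest number of the four. The entering group is larger than 4-fluorophenyl and carries hydrogen-bond acceptors that 4-fluorophenyl lacks, but nothing measured here links either feature to the lower number.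

On these data alone, whether the loss follows from the methoxy groups themselves or from where they sit on the ring stays open, and a 4-methoxyphenyl or 3,4-dimethoxyphenyl group at this carbon would bear directly on that question. These readings also come from a single dose at a single time, so they give the size of the effect at that dose and say nothing about potency.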